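This account rests on a few compounds, and the source may have more. Where it says the series, first, only, none or still open, it means among the compounds named here.

Measured compounds:
compound 1, `NC1=NC2(CCSCC2)N(OCCCOc2cccc(Cl)c2)C(N)=N1`, giving 88.3%
compound 2, `Cc1cc(C)cc(OCCCON2C(N)=NC(N)=NC23CCOCC3)c1`, giving 84.3%

Both compounds were tested in an assay on isolated protein for inhibition of Dihydrofolate reductase (Homo sapiens), read by spectrophotometry, using NADPH, with stated times of 5 s and 6 min, tested at 5 uM; a lower number here means a weaker effect, a higher number a stronger effect of the compound at the concentration tested. Compound 1 gives 88.3%, and compound 2 gives 84.3%; the gap between the two lies within the usual scatter, so the two cannot be told apart on these data.

Compound 3, `NC1=NC2(CCSCC2)N(OCCCOc2cccc(Cl)c2Cl)C(N)=N1`, has not been measured. It differs from compound 1 by a single change: chloro in place of hydrogen on an aromatic carbon. Going by the values given here, no step between measured compounds touches this position, so there is nothing in the data to calibrate the change against; what is known is only that compound 1 already gives a high read-out and that compound 2, with a different aromatic substitution and core, gives a similar one.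

The step expected a number 0.7 percentage points higher from compound 1 to compound 3 (within the scatter) is therefore small, most likely none beyond the scatter, with a slight lean upward if anything. For compound 3 the expected value in this assay is 89%, estimated to fall between 77% and 97%.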

Compound 3, a percentage reported as inhibition, at one concentration (the size of the read-out at that concentration, not a potency): 83.8%
Beside the measured number, compound 3's estimate is 5.2 percentage points above it; the range from low to high includes it.
By their numbers in this assay, from the lowest: compounds 3, 2 and 1 (each within the scatter of the next).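

In this assay, going by these compounds alone, the change from 3-chlorophenyl to 2,3-dichlorophenyl gives the first reading for this position, an aromatic carbon ortho to a chloro group and ortho to a large group, and the step is a number 4.5 percentage points lower from compound 1 to compound 3 (within the scatter) on the percentage read-out. This shows that the position can carry a chloro group, one heavy atom more than hydrogen, with no difference from the parent that can be told from the usual scatter. Since the read-out comes from one concentration and is not a potency, this says only that the high read-out survives the change at that concentration, and nothing shown accounts for the result.

The compounds shown leave open whether this carbon would accept something other than chloro, such as a methoxy group, an amine or a carboxylic acid, with the read-out staying in the same range. They also leave open whether a longer chain between the ring and the shared core, or the same chloro change on another core, would give a step of similar size.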